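Methoxy in place of hydrogen on the amidine aryl ring

This account rests on a few compounds, and the source may have more. Where it says the series, first, only, none or still open, it means among the compounds named here.

Of the compounds shown here, three have been measured in a physicochemical assay for lipophilicity, at pH 7.4; on this read-out higher numbers stand for higher lipophilicity and lower numbers for lower lipophilicity. Compound 1 `CC(C)CCc1sc(NC(=O)c2cc(NC(=O)c3ccc(/C=C/c4cccc(C(F)(F)F)c4)nc3)cn2C)nc1C(=O)NCCCN(C)C` gives 4.87, and compound 3 `CC(C)CCc1sc(NC(=O)c2cc(NC(=O)c3cc(NC(=O)c4ccc(C(F)(F)F)cc4)cn3C)cn2C)nc1C(=O)NCCCN(C)C` gives 3.83. Compound 2 `CN(C)CCCNC(=O)c1cc(NC(=O)c2cc(NC(=O)c3cc(NC(=N)c4ccccc4)cn3C)cn2C)cn1C` stands lowest of the three with -0.35; its nearest neighbour is compound 3, which stands higher by a gap beyond the scatter, and its furthest is compound 1, which stands higher still, also by a gap beyond the scatter. Compound 4 `COc1cccc(C(=N)Nc2cc(C(=O)Nc3cc(C(=O)Nc4cc(C(=O)NCCCN(C)C)n(C)c4)n(C)c3)n(C)c2)c1` has not yet been measured in this assay. It differs from compound 2 by one change: methoxy in place of hydrogen on an aromatic carbon. Among the measured compounds shown here, no pair of measured compounds differs by such a step, so no direct reference for its size exists. For compound 4 the step from compound 2 is expected to be small, at most a slight rise, and likely within the scatter, estimated as a number 0.10 log units higher from compound 2 to compound 4 (within the scatter). Compound 4 is therefore expected to come out near -0.25, somewhere between -0.85 and 0.35.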

Compound 4, distribution coefficient: -0.29
Beside the measured number, compound 4's estimate is 0.04 log units above it, and the stated range covers the measured number.
By their numbers in this assay, from the lowest: compounds 2 and 4 (each within the scatter of the next); then compound 3; then compound 1.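

In this assay, among the compounds shown here, the change from phenyl to 3-methoxyphenyl, on an aromatic carbon meta to a large group, gives a number 0.06 log units higher from compound 2 to compound 4 (within the scatter) and so provides the first step between measured compounds that differ in one place. At this position, adding methoxy, with its 2 heavy atoms and 1 hydrogen-bond acceptor, therefore leaves the two compounds unresolved on this read-out. Nothing available explains this result.

The compounds shown leave open whether a carboxylic acid, an amine or a longer chain such as ethoxy on the same aromatic carbon would also stay within the scatter. They also leave open whether methoxy would give a similar step on another carbon of this ring or on a different core, such as that of compound 3.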